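The compounds below may be only part of what the source reports. "The series", "measured", "known", "first", "only" and "open" are said of these compounds alone.

Compound 1 `CC(C)=CCc1cc(C(=O)Nc2cc3ccc(OCC4CCCN(C)C4)c(C)c3oc2=O)ccc1O` is the starting point. In a functional assay on MCF7 cells (Homo sapiens) for antiproliferative activity (a higher number here means a weaker inhibitor, a lower number a stronger inhibitor), compound 1 gives 2640 nM, the higher of the two numbers shown. Compound 2 `CC(C)=CCc1cc(C(=O)Nc2cc3ccc(OCC4CCN(C)C4)c(C)c3oc2=O)ccc1O` gives 1550 nM in this assay, and the step is a 1.7-fold lower number from compound 1 to compound 2 (0.23 log units; within the scatter). Compound 3 `CCCN(CCC)CCCOc1ccc2cc(NC(=O)c3ccc(O)c(CC=C(C)C)c3)c(=O)oc2c1C` reaches only a limit of this assay, at > 50000 nM. The steps to it are an at least 18-fold higher number from compound 1 to compound 3 (1.27 log units; beyond the scatter) and an at least 32-fold higher number from compound 2 to compound 3 (1.50 log units; beyond the scatter), so opening the ring into a chain amine cost much. Compound 4 `CC(C)=CCc1cc(C(=O)Nc2cc3ccc(OCCCNC(C)(C)C)c(C)c3oc2=O)ccc1O` makes a related change: 2-((tert-butyl)amino)ethyl in place of 1-methylpiperidin-3-yl on a saturated chain carbon bound to an oxygen on an aromatic ring. By analogy with compound 3 a large rise in the number is expected, though the ring-opened chain here is shorter, so compound 4 is estimated at 9000 nM (range 2500 nM to 40000 nM), meaning a 3.4-fold higher number from compound 1 to compound 4 (0.53 log units; beyond the scatter).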

Compound 4, half-maximal inhibitory concentration: 950 nM
Estimate against measurement, compound 4: 9.5-fold (0.98 log units) above, outside the stated range (below it).
By their numbers in this assay, from the lowest: compounds 4, 2 and 1 (each within the scatter of the next, the first and the last beyond it). At a limit, above all of these: compound 3.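

An open chain at this place is not a loss in itself: there is a 2.8-fold lower number from compound 1 to compound 4 (0.44 log units; beyond the scatter), and a 1.6-fold lower number from compound 2 to compound 4 (0.21 log units; within the scatter). What stands at the end of the chain decides the result, with (tert-butyl)amino in place of dipropylamino giving an at least 52-fold lower number from compound 3 to compound 4 (1.72 log units; beyond the scatter). Compound 3 sits at a limit, so that step is only a bound: the limit of > 50000 nM in this assay, at which 1 of the 4 values shown sits.

The compounds shown leave open whether the tert-butyl group or the hydrogen on the amine nitrogen matters here. A chain ending in isopropylamino or dimethylamino, or a longer chain, would help separate these.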